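This account rests on a few compounds, and the source may have more. Where it says the series, first, only, none or still open, it means among the compounds named here.

Measured compounds in a functional assay on OCI-Ly7 cells (Homo sapiens) for antiproliferative activity, read by WST assay, with a stated time of 3 days; on this read-out lower numbers stand for stronger inhibition and higher numbers for weaker inhibition:
- compound 1 `[N-]=[N+]=Nc1cc(=O)[nH]c(=O)n1[C@@H]1O[C@H](CO)[C@@H](O)[C@H]1O`: > 50000 nM
- compound 2 `Nc1cc(=O)[nH]c(=O)n1[C@@H]1O[C@H](CO)[C@@H](O)[C@H]1O`: > 50000 nM
- compound 3 `COC(=O)c1cc(=O)[nH]c(=O)n1[C@@H]1O[C@H](CO)[C@@H](O)[C@H]1O`: to be measured

Compound 1 gives > 50000 nM in this assay, which is a limit of the assay and not a number. Compound 2 gives > 50000 nM in this assay, again a limit of the assay and not a number. Among the measured compounds shown here, the one measured step, a step that the two limits leave unreadable from compound 1 to compound 2, cannot be read, since the limit of > 50000 nM in this assay, at which 2 of the 2 values shown sit, holds both values. Compound 2 therefore stands only at a limit, with no numerical position within the series.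

The change to compound 3 is methoxycarbonyl in place of amino on an aromatic carbon. For the measured compounds named here, no measured step bears directly on a methoxycarbonyl at this carbon; the only step available is the unreadable one between compound 1 and compound 2. Going by the values given here, with both neighbours at the limit, the expectation for compound 3 is that it also sits at or near the limit, giving no resolved step, so a number no higher from compound 2 to compound 3 (the limit leaves the size open) is the estimated step. Compound 3 is expected at 50000 nM, with a range from 15000 nM to 200000 nM.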

Compound 3, half-maximal inhibitory concentration: > 50000 nM
Compound 3: only a limit was reported; the forecaster's own chance of this, stated with the estimate: 80%; the middle value sits exactly at the limit.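

In this assay compound 3 gives > 50000 nM, a limit of the assay and not a number. No step among compound 1, compound 2 and compound 3 can be read, as all three are held at one limit: the limit of > 50000 nM in this assay, at which 3 of the 3 values shown sit.

The compounds shown leave open how azido, amino and methoxycarbonyl at this carbon rank against one another.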